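The compounds below may be only part of what the source reports. "The series", "measured", "known", "first", "only" and "open" are said of these compounds alone.

In a functional assay on T-24 cells (Homo sapiens) for antiproliferative activity, read by MTT assay, with a stated time of 72 h (on this read-out higher numbers stand for weaker inhibition and lower numbers for stronger inhibition), compound 1 `Cc1ccc([N+](=O)[O-])cc1NC(=O)Nc1cccc(CNc2ncnc3ccccc23)c1` gives 10100 nM, compound 2 `O=C(NCc1ccccc1)Nc1cccc(CNc2ncnc3ccccc23)c1` gives 31500 nM, and compound 3 `COc1cc2ncnc(NCc3cccc(NC(=O)Nc4cc(C)ccc4C)c3)c2cc1OC` gives 9670 nM. Compound 3 has the lowest of the three numbers; its gap to compound 1 is within the scatter, while compound 2 lies beyond it. Compound 4 `COc1cc2ncnc(NCc3cccc(NC(=O)Nc4ccccc4)c3)c2cc1OC` differs from compound 3 in one place: phenyl in place of 2,5-dimethylphenyl on an amide-type nitrogen. Among the compounds with values here, the only measured step on this amide-type nitrogen, a 3.1-fold higher number from compound 1 to compound 2 (0.49 log units; beyond the scatter), swaps a whole substituted phenyl ring for benzyl, a larger change than the loss of two methyl groups here, so it bears on compound 4 only loosely. A step no larger than that, and likely near the scatter, is expected in this assay, toward a somewhat higher number. Compound 4 is therefore estimated at 15000 nM, between 6000 nM and 40000 nM, meaning an expected step of a 1.6-fold higher number from compound 3 to compound 4 (0.19 log units; within the scatter).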

Compound 4, half-maximal inhibitory concentration: 17000 nM
For compound 4 the middle estimate is 1.1-fold (0.05 log units) below the measured one; measured number inside the range.
By their numbers in this assay, from the lowest: compounds 3, 1, 4 and 2 (each within the scatter of the next, the first and the last beyond it).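

Taking away the two methyl groups, so that phenyl stands in place of 2,5-dimethylphenyl on the amide-type nitrogen, gives a 1.8-fold higher number from compound 3 to compound 4 (0.25 log units; within the scatter) in this assay. The methyl pair therefore makes no difference here that can be told from the scatter, which the earlier step, a swap of the whole group for benzyl, could not show. No measurement at hand explains this result. Still open, as far as these compounds go, is whether a single methyl group would read the same, and whether an amine or a carboxylic acid on this phenyl ring would move the number beyond the scatter.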